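This account rests on a few compounds, and the source may have more. Where it says the series, first, only, none or still open, it means among the compounds named here.

Measured so far:
compound 1 `Cn1c(=O)c(S(=O)(=O)c2ccc(F)cc2F)cc2cnc(Nc3ccc4[nH]ncc4c3)nc21`: 30000 nM
compound 2 `Cn1c(=O)c(S(=O)(=O)c2ccc(F)cc2)cc2cnc(Nc3ccc4[nH]ncc4c3)nc21`: 5000 nM

Both values come from a functional assay on DU-145 cells (Homo sapiens) for inhibition, read by trypan blue exclusion, with a stated time of 72 h; on this read-out lower numbers stand for stronger inhibition and higher numbers for weaker inhibition. Compound 1 stands highest of the two numbers; the step of a 6.0-fold lower number from compound 1 to compound 2 (0.78 log units; beyond the scatter) is the only measured one. Compound 3 `Cn1c(=O)c(S(=O)(=O)c2ccc(F)cc2F)cc2cnc(Nc3ccc4c(c3)C(=O)C(=O)N4)nc21` differs from compound 1 by a group of 11 heavy atoms (8 carbon, 1 nitrogen, 2 oxygen; one five-membered non-aromatic ring with 1 hetero atom, one six-membered aromatic ring of carbon only) in place of a group of 9 heavy atoms (7 carbon, 2 nitrogen; one five-membered aromatic ring with 2 hetero atoms, one six-membered aromatic ring of carbon only), on a nitrogen on an aromatic ring. Within the data shown here, no measured step touches that part of the shared core, so the one step known, between compound 1 and compound 2, does not bear on this change. With nothing to lean on, compound 3 is expected near compound 1, at an estimated 30000 nM, range 7000 nM to 120000 nM. The step this estimate means is no change at the digits printed from compound 1 to compound 3 (within the scatter), and it is expected with wide uncertainty.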

Compound 3, half-maximal inhibitory concentration: 75000 nM
Beside the measured number, compound 3's estimate is 2.5-fold (0.40 log units) below it; measured number inside the range.
By their numbers in this assay, from the lowest: compound 2; then compound 1; then compound 3.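

In this assay the group on a nitrogen on an aromatic ring affects the read-out: the carbonyl-bearing group in place of 1H-indazol-5-yl gives a 2.5-fold higher number from compound 1 to compound 3 (0.40 log units; beyond the scatter) in a modest move toward weaker inhibition. This position is therefore not silent, and this exchange offers no gain over compound 1. No evidence bears on the origin of this step. Still open, going by these compounds, is whether an amine or a carboxylic acid on the 1H-indazol-5-yl group would lower the number, and whether the same step holds on the core of compound 2.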